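This account rests on a few compounds, and the source may have more. Where it says the series, first, only, none or still open, it means among the compounds named here.

Compound 2 `O=C(Nc1cccc(Cl)c1)Nc1cccc(CNc2nccnc2Cl)c1` shares its core with compound 1 `CN(C)c1ccc(NC(=O)Nc2cccc(CNc3nccnc3Cl)c2)cc1` and compound 3 `O=C(Nc1cccc(CNc2nccnc2Cl)c1)NC1CCCC1`; the three differ only in the group on the amide-type nitrogen. In a functional assay on T-24 cells (Homo sapiens) for antiproliferative activity, read by MTT assay, with a stated time of 48 h (on this read-out higher numbers stand for weaker inhibition and lower numbers for stronger inhibition), compound 2 gives 6810 nM, the lowest of the two full numbers. Compound 1 gives 20200 nM in this assay. For compound 3 this assay reports only a limit, > 40000 nM, so no number is known for it (the limit of > 40000 nM in this assay, at which 1 of the 3 values shown sits).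

Compound 4 `O=C(Nc1cccc(CNc2nccnc2Cl)c1)Nc1ccccc1F` has not yet been measured and differs from compound 2 in one place: 2-fluorophenyl in place of 3-chlorophenyl on an amide-type nitrogen. Among the compounds with values here, two measured steps touch the same nitrogen. Moving from 4-(dimethylamino)phenyl to 3-chlorophenyl gave a 3.0-fold lower number from compound 1 to compound 2 (0.47 log units; beyond the scatter), while moving from 3-chlorophenyl to cyclopentyl gave an at least 5.8-fold higher number from compound 2 to compound 3 (0.76 log units; beyond the scatter). Both swaps exchanged one kind of group for quite another; the move to 2-fluorophenyl keeps one six-membered aromatic ring of carbon only, so a step no larger than modest is expected, if anything toward a higher number. The estimate for compound 4 is 10000 nM, with a range from 4000 nM to 25000 nM. That corresponds to an expected step of a 1.5-fold higher number from compound 2 to compound 4 (0.17 log units; within the scatter).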

Compound 4, half-maximal inhibitory concentration: 7450 nM
For compound 4 the middle estimate is 1.3-fold (0.13 log units) above the measured one; the measured number falls inside the stated range.
By their numbers in this assay, from the lowest: compounds 2 and 4 (each within the scatter of the next); then compound 1. At a limit, above all of these: compound 3.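

Exchanging 3-chlorophenyl for 2-fluorophenyl on the amide-type nitrogen changes both the halogen and its place on the ring, yet in this assay it gives a 1.1-fold higher number from compound 2 to compound 4 (0.04 log units; within the scatter), so compounds 2 and 4 cannot be told apart. The two halogen-bearing phenyl groups therefore stand together here, and the steps to compound 4 match those seen for compound 2: a 2.7-fold lower number from compound 1 to compound 4 (0.43 log units; beyond the scatter), and an at least 5.3-fold lower number from compound 3 to compound 4 (0.72 log units; beyond the scatter). That last step has a floor rather than an exact size, as compound 3 is known only as a limit: the limit of > 40000 nM in this assay, at which 1 of the 4 values shown sits.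

With only these two halogen-bearing groups, the separate roles of the halogen and its place remain unresolved, and 2-chlorophenyl or 3-fluorophenyl would address that. Also open, going by these compounds, is how plain phenyl or a phenyl carrying a carboxylic acid would fare on this nitrogen.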